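Pyrazolopyrimidine enones: a chlorophenyl swap on the carbonyl side

A few compounds are considered here, and "the series" means these few. Any claim that something is new, unique, unknown or untested is made for them only; others in the source may bear on it.

Measured so far:
compound 1 `COc1ccc(-c2cc(/C=C/C(=O)c3cc(OC)c(OC)c(OC)c3)nc3cc(-c4ccccc4)nn23)cc1OC` gives 35000 nM in an ADME assay on HEK293 cells (Homo sapiens) for antiproliferative activity, read by MTT assay, with a stated time of 24 h; a higher number here means a weaker inhibitor, a lower number a stronger inhibitor
compound 2 `COc1cc(/C=C/C(=O)c2cc(-c3cc(OC)c(OC)c(OC)c3)n3nc(-c4ccccc4)cc3n2)cc(OC)c1OC` gives 41000 nM in this assay
compound 3 `COc1ccc(-c2cc(C(=O)/C=C/c3cc(OC)c(OC)c(OC)c3)nc3cc(-c4ccccc4)nn23)cc1OC` gives 46800 nM in this assay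

Compound 1 has the lowest of the three numbers, but its gaps to compound 2 and to compound 3 are both within the scatter, so the three stand level. Among the measured compounds shown here, the one single-site step in the set, a 1.1-fold higher number from compound 2 to compound 3 (0.06 log units; within the scatter), is also within the scatter.

Compound 4 `COc1ccc(-c2cc(/C=C/C(=O)c3ccc(Cl)cc3)nc3cc(-c4ccccc4)nn23)cc1OC` differs from compound 1 by 4-chlorophenyl in place of 3,4,5-trimethoxyphenyl on a carbonyl carbon. For the measured compounds named here, no measured step touches the ring on the carbonyl carbon, and the one step that does exist, a 1.1-fold higher number from compound 2 to compound 3 (0.06 log units; within the scatter), concerns a methoxy on a different ring, so it bears on the new change only as a sign that methoxy loss elsewhere left the number flat. Going by the values given here, with no direct precedent, the step from compound 1 to compound 4 is expected to be a 1.2-fold higher number from compound 1 to compound 4 (0.08 log units; within the scatter), that is, none beyond the scatter.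

Compound 4 is therefore estimated at 42000 nM in this assay, with a range from 15000 nM to 110000 nM.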

Compound 4, half-maximal inhibitory concentration: 44100 nM
Estimate against measurement, compound 4: 1.1-fold (0.02 log units) below, within the range that was stated.
By their numbers in this assay, from the lowest: compounds 1, 2, 4 and 3 (each within the scatter of the next).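

At the carbonyl carbon, 4-chlorophenyl in place of 3,4,5-trimethoxyphenyl gives a 1.3-fold higher number from compound 1 to compound 4 (0.10 log units; within the scatter) in this assay, so compound 4 stands level with compound 1. The entering group has 7 heavy atoms, fewer than the leaving group, and 0 hydrogen-bond acceptors against 3, yet this pair shows no step beyond the scatter. No measurement at hand accounts for this flat result.

An amine or a carboxylic acid on this ring, or a longer chain in its place, would test whether the carbonyl-side group can move the number at all. Neither step shown lies beyond the scatter, so it remains open which part of the series, if any, controls the number.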